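A few compounds are considered here, and "the series" means these few. Any claim that something is new, unique, unknown or untested is made for them only; others in the source may bear on it.

Compound 1, `S=C(SCc1cn(Cc2ccc(Cl)c(Cl)c2)nn1)N1CCNCC1`, "not determined" (no result reported).
Compound 2, `Cc1ccc(Cn2cc(CSC(=S)N3CCN(C(=O)OCc4ccccc4)CC3)nn2)cc1`, 37800 nM.

Compound 1 carries no number in a functional assay on MCF7 cells (Homo sapiens) for inhibition, read by MTT assay, with a stated time of 72 h (on this read-out lower numbers stand for stronger inhibition and higher numbers for weaker inhibition), so compound 2 stands alone as the only measured point. In this assay compound 2 gives 37800 nM, a high concentration, which on this read-out means weak inhibition of the cells. Compound 3, `Cc1ccc(Cn2cc(CSC(=S)N3CCNCC3)nn2)cc1`, has not yet been measured. It differs from compound 2 in one place: hydrogen in place of benzyloxycarbonyl on an amine nitrogen in a ring. For the measured compounds named here, no pair of measured compounds shows what this change does, so there is no measured step to lean on, and the expectation rests on compound 2 alone. The change is expected to shift this assay by a 1.5-fold higher number from compound 2 to compound 3 (0.16 log units; within the scatter), a small move toward weaker inhibition that may not clear the usual scatter. Compound 3 is therefore estimated at 55000 nM, with a plausible range from 12000 nM to 250000 nM.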

Compound 3, half-maximal inhibitory concentration: 53200 nM
Estimate against measurement, compound 3: 1.0-fold (0.01 log units) above; low and high end bracket the measured number.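

Taking off the benzyloxycarbonyl at this amine nitrogen gives the first measured step at this position, a 1.4-fold higher number from compound 2 to compound 3 (0.15 log units; within the scatter), in this assay. This step lies within the scatter, so the read-out does not tell the compound carrying the benzyloxycarbonyl, with its six-membered aromatic ring, from the compound with a plain hydrogen on that nitrogen. Neither compound shows strong inhibition of these cells, so this large group is not needed for the weak inhibition seen here, and no evidence at hand bears on this result.

On these data alone, whether a methyl or an acetyl group on this nitrogen, or a longer chain ending in a carboxylic acid, would give a step beyond the scatter stays open. Compound 1 gives "not determined" (no result reported), so the effect of the two chlorines on the benzyl end also stays unread.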